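This account rests on a few compounds, and the source may have more. Where it says the series, first, only, none or still open, it means among the compounds named here.

Measured compounds:
Compound 1, `CCCCCCCCSC[C@H](NC(C)=O)C(=O)CCl`, gives 5600 nM in a functional assay on NALM-6 cells (Homo sapiens); on this read-out higher numbers stand for weaker inhibition and lower numbers for stronger inhibition.
Compound 2, `CCCCCCCCCCSC[C@H](NC(C)=O)C(=O)CCl`, gives 4700 nM in this assay.
Compound 3, `CCCCCCCCCCCCCCCCCCCCSC[C@H](NC(C)=O)C(=O)CCl`, gives > 100000 nM in this assay; this is a limit of the assay, not a number.

All three share the same core, a chloromethyl ketone carrying an acetamide, with a sulfur linking to a straight saturated chain that grows longer from compound 1 to compound 3. The change from compound 1 to compound 2 is ethyl in place of hydrogen on a saturated chain carbon, eight bonds along the chain from a sulfur, and it made a 1.2-fold lower number from compound 1 to compound 2 (0.08 log units; within the scatter). Going by these compounds, the change from compound 2 to compound 3 is a much larger extension of the same chain, and it made an at least 21-fold higher number from compound 2 to compound 3 (1.32 log units; beyond the scatter), a step whose true size is unknown because of the limit of > 100000 nM in this assay, at which 1 of the 3 values shown sits.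

Compound 4, `CCCCCCCCCCCCCCCCCCCCCCSC[C@H](NC(C)=O)C(=O)CCl`, has not yet been measured. It differs from compound 3 by ethyl in place of hydrogen on a saturated chain carbon, ten or more bonds along the chain from a sulfur. Among the compounds with values here, this is the same kind of change as the one from compound 1 to compound 2, but the place along the chain is not the same; each of the two descriptions of the difference gives its own place. The difference between the core of compound 1 and the core of compound 3 is not broken down here.

Compound 4 is expected to stay at the limit, because compound 3 already sits at the limit of > 100000 nM in this assay, at which 1 of the 3 values shown sits, and a further lengthening of the chain is not expected to bring the number back down. The step from compound 3 to compound 4 is estimated as a step that the limit leaves unreadable from compound 3 to compound 4. Compound 4 is estimated at 150000 nM, most likely reported only as a limit, with a range from 50000 nM to 500000 nM.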

Compound 4, half-maximal inhibitory concentration: > 100000 nM
Compound 4 gave a limit, no number; the forecaster's own chance of this, stated with the estimate: 90%; the middle value is on the limit's open side.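

In this assay compound 4 gives > 100000 nM, which is a limit and not a number. The step between compound 3 and compound 4 cannot be read, because neither compound gives a number: the limit of > 100000 nM in this assay, at which 2 of the 4 values shown sit.

The compounds shown leave open how weak compound 3 and compound 4 truly are, and at what chain length between those of compound 2 and compound 3 the number starts to rise.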